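Swapping Carboxy for Bromo: Cytotoxicity in J774 Cells

A few compounds are considered here, and "the series" means these few. Any claim that something is new, unique, unknown or untested is made for them only; others in the source may bear on it.

Compound 1 `COC(=O)c1c[nH]c2cc(OCCOc3ccccc3)c(C)cc2c1=O`: > 20000 nM
Compound 2 `COC(=O)c1c[nH]c2cc(OCc3ccccc3)ccc2c1=O`: 18900 nM
Compound 3 `CCCCc1cc2c(=O)c(C(=O)O)c[nH]c2cc1OCCOc1ccccc1`: > 20000 nM

Of the compounds shown here, three have been measured in an ADME assay on J774 cells (Mus musculus) for cytotoxicity; a higher number here means that more compound is needed for the effect, a lower number that less compound is needed. For compound 1 the result > 20000 nM is a limit of the assay and not a number. Compound 2 gives 18900 nM in this assay. For compound 3 the result > 20000 nM is likewise a limit of the assay and not a number. Among the measured compounds shown here, compound 3 therefore stands at the limit of > 20000 nM in this assay, at which 2 of the 3 values shown sit, and no compound among the three is separated from it by more than the usual scatter.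

For the measured compounds named here, no pair of measured compounds differs in a single place, so no measured step shows how much a change of one group moves this read-out.

Compound 4 `CCCCc1cc2c(=O)c(Br)c[nH]c2cc1OCCOc1ccccc1` differs from compound 3 in this way: bromo in place of carboxy on an aromatic carbon.

Without a measured step of this kind, the expected change from compound 3 to compound 4 is an at least 1.4-fold lower number from compound 3 to compound 4 (0.15 log units; that floor lies within the scatter), a step toward less compound being needed that may or may not exceed the scatter. Compound 4 is estimated to give 14000 nM in this assay, with a range from 4000 nM to 40000 nM.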

Compound 4, half-maximal effective concentration: 8070 nM
Compound 4: the middle estimate sits 1.7-fold (0.24 log units) above what was measured, within the range that was stated.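

Bromo in place of carboxy on an aromatic carbon, two atoms from the ring nitrogen, gives in this assay an at least 2.4-fold lower number from compound 3 to compound 4 (0.39 log units; beyond the scatter); this is the first measured step between two compounds that differ in one place, and it lies beyond the scatter. For compound 3 the result > 20000 nM is a limit of the assay and not a number. The step therefore marks only the smallest change this swap can represent, and its full size cannot be read because the carboxy compound stands at that limit: the limit of > 20000 nM in this assay, at which 2 of the 4 values shown sit.

On these data alone, what remains open is how other groups at this position would compare, such as a chloro group, a nitrile or an amine, and so whether the step follows from the arrival of bromo or from the departure of carboxy. Also open, as far as these compounds go, is whether the same swap would give a step of similar size on a core carrying a longer chain in place of the butyl chain, or on a core with a different ether side chain.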